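Replacing the Diamine Chain End with a Nitrile

The compounds below may be only part of what the source reports. "The series", "measured", "known", "first", "only" and "open" are said of these compounds alone.

Compound 2 `NCC(N)CCc1c[nH]c2ccc(F)cc12` stands as the weaker of the two compounds measured: in an assay on isolated protein (urine) for inhibition of Myeloperoxidase (Homo sapiens), with a stated time of 5 min (a lower number here means a stronger inhibitor, a higher number a weaker inhibitor), compound 2 gives 60 nM, while compound 1 `NCCSCCc1c[nH]c2ccc(F)cc12` gives 4 nM. For the measured compounds named here, the single measured step, a 15-fold higher number from compound 1 to compound 2 (1.18 log units; beyond the scatter), shows that changing the chain end can shift the number strongly. Compound 3 `N#CCCCc1c[nH]c2ccc(F)cc12` carries cyanomethyl in place of 1,2-diaminoethyl on a saturated chain carbon, two bonds along the chain from an aromatic carbon. Going by the values given here, no measured compound lacks an amine on its chain, so the direction rests on the change alone; a weakening is expected, estimated at a 17-fold higher number from compound 2 to compound 3 (1.22 log units; beyond the scatter). Compound 3 is therefore expected to give 1000 nM in this assay, within 150 nM to 8000 nM.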

Compound 3, half-maximal inhibitory concentration: 63 nM
Compound 3: the middle estimate sits 16-fold (1.20 log units) above what was measured, and the stated range ends above it.
By their numbers in this assay, from the lowest: compound 1; then compounds 2 and 3 (each within the scatter of the next).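

The step of a 1.1-fold higher number from compound 2 to compound 3 (0.02 log units; within the scatter) shows that on this saturated chain carbon, cyanomethyl, with 0 hydrogen-bond donors, matches 1,2-diaminoethyl, so neither amine of that chain end is required to reach this level. Even so, a 16-fold higher number from compound 1 to compound 3 (1.20 log units; beyond the scatter), which leaves (2-aminoethyl)sulfanyl with the lowest number of the three. No available evidence accounts for these results. Still open, going by these compounds, is whether the low number of compound 1 depends on its chain sulfur atom or on its end amine. A plain carbon chain ending in a single amine, or a carboxylic acid at the chain end, would be informative here.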